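The source may report more compounds than this note shows. Statements on the series, on what has been measured and on what is new or still open speak of the compounds shown alone.

Among the measured compounds shown here, compound 3 `C[C@H](CF)OC(=O)N1CCC(O[C@H]2CC[C@H](Oc3cnc(S(C)(=O)=O)cn3)CC2)CC1` gives 36.8 nM in a functional assay on isolated protein for agonist activity at Glucose-dependent insulinotropic receptor (Homo sapiens), read by HTRF and cAMP accumulation (a higher number here means that more compound is needed for the effect, a lower number that less compound is needed), the highest of the three numbers known. Compound 1 `CC(C)(C)OC(=O)N1CCC(O[C@H]2CC[C@H](Oc3ccc(S(C)(=O)=O)cc3)CC2)CC1` gives 16.1 nM in this assay, and compound 2 `CC(C)OC(=O)N1CCC(O[C@H]2CC[C@H](Oc3cnc(S(C)(=O)=O)cn3)CC2)CC1` gives 13.7 nM. For the measured compounds named here, the only single step among them, a 2.7-fold higher number from compound 2 to compound 3 (0.43 log units; beyond the scatter), touches the same oxygen next to the carbonyl but swaps only a hydrogen for fluorine. Going by the values given here, compound 4 `CS(=O)(=O)c1cnc(O[C@H]2CC[C@H](OC3CCN(C(=O)Oc4ccccc4)CC3)CC2)cn1` differs from compound 3 by phenyl in place of 1-(fluoromethyl)ethyl on an oxygen next to a carbonyl group, a change of a different kind, for which no measured step exists. Since compound 1 and compound 2 show that varying the group on that oxygen left the numbers near one another, compound 4 is expected to return toward them, with an estimated 1.8-fold lower number from compound 3 to compound 4 (0.26 log units; within the scatter). Compound 4 is estimated at 20 nM, within 7 nM to 60 nM.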

Compound 4, half-maximal effective concentration: 9.6 nM
For compound 4 the middle estimate is 2.1-fold (0.32 log units) above the measured one; the range from low to high includes it.
By their numbers in this assay, from the lowest: compounds 4, 2 and 1 (each within the scatter of the next); then compound 3.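

On an oxygen next to a carbonyl group, an aromatic ring of carbon only now appears, and in this assay the step to phenyl from isopropyl, a 1.4-fold lower number from compound 2 to compound 4 (0.15 log units; within the scatter), stays within the scatter. Phenyl in place of 1-(fluoromethyl)ethyl gives a 3.8-fold lower number from compound 3 to compound 4 (0.58 log units; beyond the scatter), a step beyond the scatter, so among compound 2, compound 3 and compound 4 the fluorinated group alone stands apart. Nothing available explains these numbers. The compounds shown leave open whether a chloro or methoxy group on the phenyl would keep this number. They also leave open how a pyridine or cyclohexyl ring would compare with phenyl here.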